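The source may hold more compounds than are shown below. What is called first, only, known or untested is meant among the compounds shown, and "the series" means these compounds.

Measured compounds:
- Compound 1 `CCCCCCCCCCCCO/N=C(\CCCCCC)c1cc(OC)c2c(c1OC)C(=O)C=CC2=O`: 0.193 ug/mL
- Compound 2 `COc1cc(/C=N/OCc2ccccc2)c(OC)c2c1C(=O)C=CC2=O`: 0.264 ug/mL

In a functional assay on L1210 cells (Mus musculus) for antiproliferative activity (a higher number here means that more compound is needed for the effect, a lower number that less compound is needed), compound 1 gives 0.193 ug/mL, the lower of the two numbers here, and compound 2 gives 0.264 ug/mL, a gap that sits within the scatter, so no order between them can be claimed.

Compound 3 `CCCCCCCCCO/N=C(\CCCCCC)c1cc(OC)c2c(c1OC)C(=O)C=CC2=O` is not yet measured. It differs from compound 1 by hydrogen in place of propyl on a saturated chain carbon, nine bonds along the chain from an oxygen on an unsaturated carbon, that is, a shorter chain on the same core. Going by the values given here, no pair that differs in one place has been measured here, so the step is expected to stay within the scatter, with no clear direction: the step from compound 1 to compound 3 is estimated as a 1.1-fold higher number from compound 1 to compound 3 (0.06 log units; within the scatter). Compound 3 is therefore expected to give about 0.22 ug/mL, somewhere between 0.08 ug/mL and 0.6 ug/mL.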

Compound 3, concentration for half-maximal effect: 1.15 ug/mL
The estimate for compound 3 lay 5.2-fold (0.72 log units) below the measured number; measured number above the stated range.
By their numbers in this assay, from the lowest: compounds 1 and 2 (each within the scatter of the next); then compound 3.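

In this assay, replacing propyl with hydrogen on a saturated chain carbon, nine bonds along the chain from an oxygen on an unsaturated carbon, shortens the chain and raises the number (a 6.0-fold higher number from compound 1 to compound 3 (0.78 log units; beyond the scatter)). Going by these compounds alone, this is the first step here that lies beyond the scatter, so the length of this chain matters on this core, at least for this pair. No measurement here explains the change.

On these data alone, it remains open whether the number changes gradually or abruptly between these two chain lengths. As far as these compounds go, it is also open whether a longer chain, or a chain ending in an amine or a carboxylic acid, would lower or raise the number.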